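The source may hold more compounds than are shown below. What is called first, only, known or untested is meant among the compounds shown, and "the series" means these compounds.

Among the compounds with values here, compound 2 `COc1ccc(F)cc1CNCCCNc1ccnc2cc(Cc3cc(C)cc(C)c3)ccc12` gives the lower of the two numbers measured so far in an ADME assay for permeability, using PAMPA, with a stated time of 30 min, at pH 7.4; on this read-out higher numbers stand for higher permeability and lower numbers for lower permeability: compound 2 gives 23 10^-6 cm/s, whereas compound 1 `COc1ccc(F)cc1CNCCCNc1ccnc2cc(Oc3cccc(N(C)C)c3)ccc12` gives 317 10^-6 cm/s. Within the data shown here, the single measured step joins these two: a 14-fold lower number from compound 1 to compound 2 (1.14 log units; beyond the scatter). Compound 3 `COc1ccc(F)cc1CNCCCNc1ccnc2cc(-c3ccccc3)ccc12` has not yet been measured in this assay. It differs from compound 2 in one place: phenyl in place of 3,5-dimethylbenzyl on an aromatic carbon. Among the measured compounds shown here, the measured step does not cover this change: it swapped 3-(dimethylamino)phenoxy for 3,5-dimethylbenzyl, whereas the step to compound 3 swaps 3,5-dimethylbenzyl for phenyl, so there is no direct precedent among the measured compounds for its direction or size. Since compound 1 with its 3-(dimethylamino)phenoxy group reached 317 10^-6 cm/s and compound 2 stands at the bottom of the two, a modest rise is expected as more likely than a further fall, though with wide uncertainty. The step expected from this change is a 2.6-fold higher number from compound 2 to compound 3 (0.42 log units; beyond the scatter). For compound 3 the estimate in this assay is 60 10^-6 cm/s, with a range from 15 10^-6 cm/s to 240 10^-6 cm/s.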

Compound 3, apparent permeability: 237 10^-6 cm/s
Compound 3: middle estimate off by 4.0-fold (0.60 log units), on the low side; measured number inside the range.
By their numbers in this assay, from the lowest: compound 2; then compounds 3 and 1 (each within the scatter of the next).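

In this assay, replacing 3,5-dimethylbenzyl with phenyl on the same aromatic carbon gives a 10-fold higher number from compound 2 to compound 3 (1.01 log units; beyond the scatter) and shows that this position can respond strongly to a change of group, even when the group that enters is a smaller carbon-only aromatic ring. Compound 2 now stands alone at the low end, since the other comparison, a 1.3-fold lower number from compound 1 to compound 3 (0.13 log units; within the scatter), shows no separation between phenyl and 3-(dimethylamino)phenoxy, so neither the dimethylamino group nor the oxygen link is required for a number at this level among these three compounds. Nothing available explains why the 3,5-dimethylbenzyl compound stands apart.

The step to phenyl removes the methyl groups and the carbon link together, so these compounds cannot show which of the two changes matters, and plain benzyl or 3,5-dimethylphenyl at this position would be needed to separate them. From the compounds shown here alone, it also remains open whether the number holds when the phenyl ring carries a charged group such as a carboxylic acid or a primary amine.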